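Working notes on a four-compound series

A few compounds are considered here, and "the series" means these few. Any claim that something is new, unique, unknown or untested is made for them only; others in the source may bear on it.

Values in a functional assay on HOP-62 cells (Homo sapiens) for cytotoxicity, read by resazurin assay, with a stated time of 72 h; a higher number here means a weaker inhibitor, a lower number a stronger inhibitor:
compound 1 `O=C(/C=C/c1ccc(OCCCCO[N+](=O)[O-])c(O)c1)OCCCCO[N+](=O)[O-]`: > 50000 nM
compound 2 `O=C(/C=C/c1ccc(OCCCCCCO[N+](=O)[O-])c(O)c1)OCCCCCCO[N+](=O)[O-]`: > 50000 nM
compound 3 `COc1cc(/C=C/C(=O)OCCCCO[N+](=O)[O-])ccc1OCCCCO[N+](=O)[O-]`: > 50000 nM

The value of compound 1 is a limit of this assay, not a number. The same holds for compound 2. The same holds for compound 3. The change methyl in place of hydrogen on an oxygen on an aromatic ring gives a step that the two limits leave unreadable from compound 1 to compound 3. The difference between the core of compound 1 and the core of compound 2 is not broken down here.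

Compound 4 `COc1cc(/C=C/C(=O)OCCCCCCO[N+](=O)[O-])ccc1OCCCCCCO[N+](=O)[O-]` is not yet measured in this assay. It differs from compound 2 by methyl in place of hydrogen on an oxygen on an aromatic ring, the same change as from compound 1 to compound 3. Because of the limit of > 50000 nM in this assay, at which 3 of the 3 values shown sit, no readable step for this change is available. The step that the limit leaves unreadable from compound 2 to compound 4 is expected to stay within that limit. For compound 4 the estimate is 60000 nM, most likely again reported as a limit.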

Compound 4, half-maximal inhibitory concentration: > 50000 nM
Compound 4 ended at the assay's limit; the forecaster's own chance of this, stated with the estimate: 85%; the middle value is on the limit's open side.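

Compound 2 and compound 4 both sit at a limit, not a number, so no step can be read between them: the limit of > 50000 nM in this assay, at which 4 of the 4 values shown sit.

Whether hydroxy to methoxy changes cytotoxicity at all stays open, with no compound shown giving a readable number.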